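Dimethylcarbamoyl for allyloxy: expected shift in the series

The source may report more compounds than this note shows. Statements on the series, on what has been measured and on what is new or still open speak of the compounds shown alone.

Two compounds of the series have numbers in an assay on Cortex with Norepinephrine transporter (Rattus norvegicus) as the target; a lower number here means a stronger inhibitor, a higher number a weaker inhibitor. Compound 1 `CN1CC[C@H](c2ccc(Cl)cc2)[C@@H](C(=O)OCCCCCc2ccccc2)C1` gives 382 nM. Among the compounds with values here, compound 2 `C=CCOC[C@H]1CN(C)CC[C@@H]1c1ccc(Cl)cc1` gives 20 nM, the lowest of the two numbers and beyond the scatter from compound 1; no step between these two is computed, since they differ in more than one place. Compound 3 `CN1CC[C@H](c2ccc(Cl)cc2)[C@@H](CC(=O)N(C)C)C1` is not yet measured. It differs from compound 2 by dimethylcarbamoyl in place of allyloxy on a saturated chain carbon bound to a saturated ring carbon. Within the data shown here, the only guide is that compound 1, which also carries a carbonyl, gives 382 nM, a weaker number than compound 2. The step of a 7.5-fold higher number from compound 2 to compound 3 (0.88 log units; beyond the scatter) is expected to run toward a higher number and to be of moderate size, beyond the scatter. The estimate for compound 3 is 150 nM, with a range from 40 nM to 600 nM.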

Compound 3, inhibition constant: 46 nM
Beside the measured number, compound 3's estimate is 3.3-fold (0.51 log units) above it; low and high end bracket the measured number.
By their numbers in this assay, from the lowest: compound 2; then compound 3; then compound 1.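

In this assay the change to dimethylcarbamoyl in place of allyloxy on a saturated chain carbon bound to a saturated ring carbon gives a 2.3-fold higher number from compound 2 to compound 3 (0.36 log units; beyond the scatter) and is modest in size. Within the data shown here, compound 1 also carries a carbonyl but differs from compound 2 in more than one place, so this pair gives the first single-change reading at this position, where a carbonyl-bearing group costs little in this comparison. No measurement at hand accounts for the step.

The pair does not separate the contribution of the carbonyl from that of the amide nitrogen, nor show whether the ether oxygen of allyloxy matters. A primary amine, a carboxylic acid or a longer ether chain at this place would show how far the trend extends.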